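Shifting the fluorines on the benzyl arm of compound 1

A few compounds are considered here, and "the series" means these few. Any claim that something is new, unique, unknown or untested is made for them only; others in the source may bear on it.

Compound 1 `COc1ccc2[nH]c3c(c2c1)CCNC31CCN(Cc2ccccc2)CC1` carries an unsubstituted benzyl group on the amine nitrogen of its piperidine ring. In an assay on FRT cells for positive allosteric modulation of Cystic fibrosis transmembrane conductance regulator variant N1303K (Homo sapiens), in the presence of a further agent that is not named here (on this read-out higher numbers stand for an effect only at larger amounts of compound and lower numbers for an effect already at smaller amounts), compound 1 gives 12600 nM, the highest of the three numbers recorded. Its nearest neighbour is compound 3 `COc1ccc2[nH]c3c(c2c1)CCNC31CCN(Cc2cc(F)ccc2F)CC1`, which gives 11100 nM in this assay, and its furthest is compound 2 `COc1ccc2[nH]c3c(c2c1)CCNC31CCN(Cc2ccc(Cl)cc2Cl)CC1`, which gives 1800 nM in this assay. The step of a 7.0-fold lower number from compound 1 to compound 2 (0.85 log units; beyond the scatter) is the one clear movement here, whereas a 1.1-fold lower number from compound 1 to compound 3 (0.06 log units; within the scatter) stays flat.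

Compound 4 `COc1ccc2[nH]c3c(c2c1)CCNC31CCN(Cc2cc(F)cc(F)c2)CC1` differs from compound 1 by 3,5-difluorophenyl in place of phenyl on a saturated chain carbon bound to an amine nitrogen in a ring. For the measured compounds named here, two measured steps bear on this change. The 2,5-difluorophenyl analogue moved nothing, as a 1.1-fold lower number from compound 1 to compound 3 (0.06 log units; within the scatter) shows, while only the 2,4-dichlorophenyl analogue brought a real gain, as a 7.0-fold lower number from compound 1 to compound 2 (0.85 log units; beyond the scatter) shows. With two fluorines rather than two chlorines, compound 4 is expected to sit closer to compound 3 than to compound 2, giving an expected step of a 1.4-fold lower number from compound 1 to compound 4 (0.15 log units; within the scatter) in this assay. Compound 4 is therefore estimated at 9000 nM in this assay, within a range from 3500 nM to 20000 nM.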

Compound 4, half-maximal effective concentration: 11100 nM
Compound 4: the middle estimate sits 1.2-fold (0.09 log units) below what was measured, and the stated range covers the measured number.
By their numbers in this assay, from the lowest: compound 2; then compounds 3, 4 and 1 (each within the scatter of the next).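

In this assay the two fluorine patterns read alike, with no change at the digits printed from compound 3 to compound 4 (within the scatter) and with a 1.1-fold lower number from compound 1 to compound 4 (0.06 log units; within the scatter) as well, so neither difluorophenyl group on this benzyl arm separates from plain phenyl. Compound 2 now stands apart from a second difluorinated partner, with a 6.2-fold higher number from compound 2 to compound 4 (0.79 log units; beyond the scatter) showing that the 3,5-difluorophenyl group does not share the gain seen with 2,4-dichlorophenyl. Nothing available here explains why compound 2 differs from the other three.

On these data alone, what a 2,4-difluorophenyl or a 3,5-dichlorophenyl group would give on this carbon stays open, and with it whether the identity of the halogen or its placement on the ring sets compound 2 apart. Also open, as far as these compounds go, is how a 4-chlorophenyl group, with a single chlorine, would compare.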